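This account rests on a few compounds, and the source may have more. Where it says the series, first, only, none or still open, it means among the compounds named here.

Of the compounds shown here, three have so far been measured in a functional assay on HepG2 cells (Homo sapiens) for inhibition, read by MTT assay, with a stated time of 48 h; a higher number here means a weaker inhibitor, a lower number a stronger inhibitor. Compound 1 `COc1ccc(C(=O)C=CNc2cc(-c3ccccc3)nn2-c2ccccc2)cc1` gives 2030 nM, the lowest number of the three. Compound 2 `COc1ccc(-c2ccnc3c2c(-c2ccccc2)nn3-c2ccccc2)cc1` gives 6590 nM, and compound 3 `CN1CCN(c2ccc(-c3c(C#N)c(-c4ccc(Cl)cc4)nc4c3c(-c3ccccc3)nn4-c3ccccc3)cc2)CC1` gives 14600 nM. Both of these gaps from compound 1 lie beyond the usual scatter of repeated measurements, so compound 1 is the strongest inhibitor of this small set.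

The next compound to be tested, compound 4 `O=C(C=CNc1cc(-c2ccccc2)nn1-c1ccccc1)c1cccs1`, keeps everything in compound 1 except one group: thiophen-2-yl in place of 4-methoxyphenyl on a carbonyl carbon. Put simply, thiophen-2-yl stands in place of 4-methoxyphenyl on a carbonyl carbon, while the shared core stays untouched.

For the measured compounds named here, no two measured compounds differ in only one place, so the data offer no direct reading of what this swap does, and any forecast is loose. Compound 1, at 2030 nM, already holds the lowest number seen, so a move upward seems a little more likely than a move downward, although neither can be ruled out. The expected size of the change is modest: the estimated step of a 1.5-fold higher number from compound 1 to compound 4 (0.17 log units; within the scatter) points toward slightly weaker inhibition and may not clear the scatter. For compound 4 the estimated value is 3000 nM, with an expected range of 1000 nM to 9000 nM.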

Compound 4, half-maximal inhibitory concentration: 2420 nM
Beside the measured number, compound 4's estimate is 1.2-fold (0.09 log units) above it; the measured number falls inside the stated range.
By their numbers in this assay, from the lowest: compounds 1 and 4 (each within the scatter of the next); then compound 2; then compound 3.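

In this assay, for the compounds shown here, the swap of 4-methoxyphenyl for thiophen-2-yl on the carbonyl carbon gives the first direct reading at this position (a 1.2-fold higher number from compound 1 to compound 4 (0.08 log units; within the scatter)), and the two compounds read alike. At this place, then, a five-membered aromatic ring with one sulfur atom and 5 heavy atoms can stand in for a six-membered aromatic ring of carbon carrying a methoxy group, 8 heavy atoms in all, without a difference that can be told from the scatter, so the 4-methoxyphenyl group is not essential to the level of inhibition seen with compound 1. Why the two groups read alike cannot be said, as no supporting data bear on it.

On these data alone, this single swap keeps an aromatic ring on the carbonyl carbon, so it remains open how the position responds to something of another kind, such as a cyclohexyl ring, a plain methyl group or a chain ending in an amine. As far as these compounds go, it also remains open whether other thiophene attachments, such as thiophen-3-yl, or a furan-2-yl ring would read the same.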